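A few compounds are considered here, and "the series" means these few. Any claim that something is new, unique, unknown or untested is made for them only; others in the source may bear on it.

Measured so far in a functional assay on BaF3 cells (Mus musculus) for antiproliferative activity; on this read-out higher numbers stand for an effect only at larger amounts of compound and lower numbers for an effect already at smaller amounts:
- compound 1 `CCN1CCN(Cc2ccc(NC(=O)c3ccc(C)c(C#Cc4ccc(C(=O)NC)nc4)c3)cc2C(F)(F)F)CC1`: 3980 nM
- compound 2 `CCN1CCN(Cc2ccc(NC(=O)c3ccc(C)c(C#Cc4cnc5[nH]ccc5c4)c3)cc2C(F)(F)F)CC1`: 1000 nM

Compound 2 has the lower of these two numbers, so it shows its effect at smaller amounts than compound 1. The next compound, compound 3 `CCN1CCN(Cc2ccc(NC(=O)c3ccc(C)c(C#Cc4cnc5[nH]c(C)cc5c4)c3)cc2C(F)(F)F)CC1`, differs from compound 2 in a single place: methyl in place of hydrogen on an aromatic carbon. In words, this is methyl in place of hydrogen on an aromatic carbon.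

Going by the values given here, only one measured step is available as a guide: a 4.0-fold lower number from compound 1 to compound 2 (0.60 log units; beyond the scatter). That step exchanged a whole group on a triple-bonded carbon, so it was a much larger structural change, and its effect was still modest. Among the compounds with values here, no measured pair tests a methyl at this place, so the data give no direction for the change. A single added methyl is therefore expected to shift this assay less than compound 2 moved from compound 1 in that step, most likely staying within the scatter. The expected change is a 1.1-fold lower number from compound 2 to compound 3 (0.05 log units; within the scatter). For compound 3 the estimated value is 900 nM, with an expected range from 300 nM to 3000 nM.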

Compound 3, half-maximal effective concentration: 1000 nM
Beside the measured number, compound 3's estimate is 1.1-fold (0.05 log units) below it, within the range that was stated.
By their numbers in this assay, from the lowest: compounds 2 and 3 (each within the scatter of the next); then compound 1.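

In this assay, a methyl on the aromatic carbon next to the ring nitrogen gives no change at the digits printed from compound 2 to compound 3 (within the scatter), so this one position of the five-membered aromatic ring can carry an added carbon with no visible shift in the number. The advantage of the two-ring group over the group in compound 1 also survives this addition, with a 4.0-fold lower number from compound 1 to compound 3 (0.60 log units; beyond the scatter), a step of the same size as a 4.0-fold lower number from compound 1 to compound 2 (0.60 log units; beyond the scatter). No measurement at hand offers an explanation for the flat result at this carbon.

On these data alone, a single methyl is only the smallest carbon group, so it remains open whether an ethyl, a longer chain, an amine or a carboxylic acid on the same carbon would also leave the number in this assay unmoved or would shift it beyond the scatter. The compounds shown also leave open whether a methyl on any other carbon of this ring would behave as this one does, since the present comparison covers one place only.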